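Trifluoromethyl for Hydroxy on the Aryl Urea of Compound 3

This account rests on a few compounds, and the source may have more. Where it says the series, first, only, none or still open, it means among the compounds named here.

Three analogues sharing one core have been measured in a functional assay on CCRF-CEM cells (Homo sapiens) for inhibition, read by MTT assay, with a stated time of 72 h; on this read-out higher numbers stand for weaker inhibition and lower numbers for stronger inhibition. Compound 1 `COc1cc(NC(C)CCCNC(=O)Nc2cccc(F)c2)c2ncccc2c1` gives 21000 nM, compound 2 `COc1cc(NC(C)CCCNC(=O)NNC(=O)Nc2ccc(Cl)cc2)c2ncccc2c1` gives 108000 nM, and compound 3 `COc1cc(NC(C)CCCNC(=O)Nc2cccc(O)c2)c2ncccc2c1` gives 32000 nM. Compound 3 thus holds the second highest of the three numbers: the gap to compound 1, a 1.5-fold higher number from compound 1 to compound 3 (0.18 log units; within the scatter), lies within the scatter, while the gap to compound 2, a 3.4-fold lower number from compound 2 to compound 3 (0.53 log units; beyond the scatter), lies beyond it.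

Compound 4 `COc1cc(NC(C)CCCNC(=O)Nc2cccc(C(F)(F)F)c2)c2ncccc2c1` arises from compound 3 by the change (trifluoromethyl in place of hydroxy on an aromatic carbon). For the measured compounds named here, the one measured step that bears on it is the exchange of substituents on the same aromatic carbon, a 1.5-fold higher number from compound 1 to compound 3 (0.18 log units; within the scatter), which stayed within the scatter; the larger step of a 5.1-fold higher number from compound 1 to compound 2 (0.71 log units; beyond the scatter) concerns a different part of the molecule. The expectation is therefore a step of a 1.6-fold lower number from compound 3 to compound 4 (0.20 log units; within the scatter) in this assay, not clearly beyond the scatter. Compound 4 is estimated at 20000 nM, with a range from 7000 nM to 55000 nM.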

Compound 4, half-maximal inhibitory concentration: 19000 nM
Compound 4: middle estimate off by 1.1-fold (0.02 log units), on the high side; the measured number falls inside the stated range.
By their numbers in this assay, from the lowest: compounds 4, 1 and 3 (each within the scatter of the next); then compound 2.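

In this assay this aromatic carbon now carries three different groups with no step beyond the scatter: a 1.7-fold lower number from compound 3 to compound 4 (0.23 log units; within the scatter) and a 1.1-fold lower number from compound 1 to compound 4 (0.04 log units; within the scatter) both stay within it, so trifluoromethyl, hydroxy and fluoro cannot be told apart here, even though trifluoromethyl brings 4 heavy atoms and 0 hydrogen-bond donors where hydroxy has 1 heavy atom and 1 hydrogen-bond donor. For the compounds shown here, the change on the amide-type nitrogen remains the one that moves the number beyond the scatter, as in a 5.7-fold lower number from compound 2 to compound 4 (0.75 log units; beyond the scatter) where 3-(trifluoromethyl)phenyl replaces ((4-chlorophenyl)carbamoyl)amino. Nothing given here offers an explanation for why the three groups read alike.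

From the compounds shown here alone, whether an amine or a carboxylic acid on this carbon would also leave the number unmoved remains open. So does whether a longer chain in place of the one joining the shared core to the urea would shift the number beyond the scatter.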